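Replacing the phenyl of compound 2 with methylsulfanyl

A few compounds are considered here, and "the series" means these few. Any claim that something is new, unique, unknown or untested is made for them only; others in the source may bear on it.

Compound 1 `O=c1cc(N2CCNCC2)oc2ccccc12`: 240000 nM
Compound 2 `Cc1c(OCc2ccccc2)ccc2c(N3CCNCC3)cc(=O)oc12`: 1100 nM
Compound 3 `COCOc1ccc2c(N3CCNCC3)cc(=O)oc2c1C`: 3500 nM

In a functional assay on a cell-free system (plasma, Homo sapiens) for inhibition, with Plasma (Rattus norvegicus) as the target (on this read-out higher numbers stand for weaker inhibition and lower numbers for stronger inhibition), compound 2 holds the lowest of the three numbers, at 1100 nM. Compound 3 is its nearest neighbour on the scale, and compound 1 lies furthest away.

Compound 4 `CSCOc1ccc2c(N3CCNCC3)cc(=O)oc2c1C` has not yet been measured. It differs from compound 2 as follows: methylsulfanyl in place of phenyl on a saturated chain carbon bound to an oxygen on an aromatic ring. In words, methylsulfanyl stands in place of phenyl on a saturated chain carbon bound to an oxygen on an aromatic ring, so that benzyloxy becomes (methylsulfanyl)methoxy.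

For the measured compounds named here, one measured step bears on this change. With methoxy in place of phenyl at that same place, the result was a 3.2-fold higher number from compound 2 to compound 3 (0.50 log units; beyond the scatter), a modest step beyond the scatter. Going by the values given here, the measurements include no other group at this place, and none that contains sulfur, so this single step is the only guide. A step of similar size and in the same direction, towards weaker inhibition, is therefore expected in this assay.

The expected change is a 2.7-fold higher number from compound 2 to compound 4 (0.44 log units; beyond the scatter). The estimated value for compound 4 is 3000 nM, with an expected range from 1200 nM to 8000 nM.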

Compound 4, half-maximal inhibitory concentration: 3400 nM
The estimate for compound 4 lay 1.1-fold (0.05 log units) below the measured number, and the stated range covers the measured number.
By their numbers in this assay, from the lowest: compound 2; then compounds 4 and 3 (each within the scatter of the next); then compound 1.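

In this assay the second small group tried on a saturated chain carbon bound to an oxygen on an aromatic ring gives a 3.1-fold higher number from compound 2 to compound 4 (0.49 log units; beyond the scatter) and so again lies beyond the scatter, which means that compound 3 no longer stands alone as the only replacement of phenyl on the side of weaker inhibition. The two replacements themselves cannot be told apart, with a 1.0-fold lower number from compound 3 to compound 4 (0.01 log units; within the scatter) within the scatter, so in this assay exchanging the methoxy of compound 3 for the methylsulfanyl of compound 4 leaves the read-out where it was. Across these three compounds, then, the sulfur-bearing group and the oxygen-bearing group read alike, and both remain modestly weaker than the benzyloxy compound, although nothing available accounts for either observation.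

The compounds shown leave open whether it is the aromatic ring of phenyl that matters, since a cyclohexyl or pyridyl group at this place would separate a ring in general from that particular ring. They also leave open how a longer chain such as ethylsulfanyl, or an amine at the same carbon, would read against compound 2 and compound 4.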